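The source may hold more compounds than are shown below. What is called first, only, known or untested is meant among the compounds shown, and "the series" means these compounds.

Of the compounds shown here, two built on a shared core have been tested so far in a functional assay on HT-29 cells (Homo sapiens) for cytotoxicity, read by MTT assay, with a stated time of 24 h, tested at 16 ug/mL; a lower number here means a weaker effect, a higher number a stronger effect of the compound at the concentration tested. Compound 1 `Cn1c(-c2ccc(NC(=O)CSc3nc4ccccc4s3)cc2)nc(-c2ccccc2)c1-c1ccccc1` gives 47.2% in this assay. Going by the values given here, compound 2 `CN1CCN(CC(=O)Nc2ccc(-c3nc(-c4ccccc4)c(-c4ccccc4)n3C)cc2)CC1` gives 33.7% in this assay, the lowest of the two numbers; the single measured step between the pair runs a number 13.5 percentage points lower from compound 1 to compound 2 (beyond the scatter). Compound 3 `CN(C)/C=C/N1CCN(CC(=O)Nc2ccc(-c3nc(-c4ccccc4)c(-c4ccccc4)n3C)cc2)CC1` has not yet been measured. It differs from compound 2 in one place: 2-(dimethylamino)ethenyl in place of methyl on an amine nitrogen in a ring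

Among the compounds with values here, no measured step bears directly on this change. Within the data shown here, the only step on record, a number 13.5 percentage points lower from compound 1 to compound 2 (beyond the scatter), concerns a saturated chain carbon bound to a carbonyl carbon, whereas compound 3 differs from compound 2 on an amine nitrogen in a ring, so that step gives no guide to the direction or size of the new one. With nothing to point either way, the expected step is a number 1.3 percentage points higher from compound 2 to compound 3 (within the scatter), which is none beyond the scatter. Compound 3 is therefore estimated to give 35% in this assay, with a range from 20% to 50%.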

Compound 3, a percentage reported as activity, at one concentration (the size of the read-out at that concentration, not a potency): 28.2%
Compound 3: the middle estimate sits 6.8 percentage points above what was measured, and the stated range covers the measured number.
By their numbers in this assay, from the lowest: compounds 3 and 2 (each within the scatter of the next); then compound 1.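

In this assay, the ring amine nitrogen of the piperazine takes 2-(dimethylamino)ethenyl, with 5 heavy atoms, in place of methyl, with 1, and the result is a number 5.5 percentage points lower from compound 2 to compound 3 (within the scatter); at this position, then, the larger group and its added double bond leave the read-out within the usual scatter. Set against compound 1, the swap of (1,3-benzothiazol-2-yl)sulfanyl for 4-(2-(dimethylamino)ethenyl)piperazin-1-yl gives a number 19 percentage points lower from compound 1 to compound 3 (beyond the scatter), so both compounds with a substituted piperazine now stand beyond the scatter from compound 1, whichever of these two groups sits on that nitrogen. No measurement of any property is available to explain this result.

Still open, as far as these compounds go, is whether other groups on the same nitrogen, such as a saturated 2-(dimethylamino)ethyl, a simple hydrogen or a carboxylic acid on a short chain, would also stay within the scatter of compound 2. From the compounds shown here alone, each number is also a read-out at a single concentration, so it shows only the size of the effect at that concentration, and whether these compounds would show a stronger or weaker effect relative to one another at other concentrations remains unknown.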